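The source may report more compounds than this note shows. Statements on the series, on what has been measured and on what is new or still open speak of the compounds shown alone.

The measured compounds in an assay for binding affinity to dual specificity mitogen-activated protein kinase kinase 4 (Homo sapiens), read by KINOMEscan, tested at 10 nM; a lower number here means a stronger effect, a higher number a weaker effect of the compound at the concentration tested:
compound 1, `CCCS(=O)(=O)Nc1ccc(F)c(C(=O)c2n[nH]c3ncc(-c4ccc(S(N)(=O)=O)cc4)cc23)c1F`, 5.1%
compound 2, `CCCS(=O)(=O)Nc1ccc(F)c(C(=O)c2n[nH]c3ncc(-c4ccc(S(=O)(=O)NC)cc4)cc23)c1F`, 14%
compound 3, `CCCS(=O)(=O)Nc1ccc(F)c(C(=O)c2n[nH]c3ncc(-c4ccc(-c5nnn[nH]5)cc4)cc23)c1F`, 1.1%

Compound 3 stands lowest of the three numbers. Compound 1 lies nearest: a number 4 percentage points lower from compound 1 to compound 3 (within the scatter). Compound 2 lies furthest: a number 12.9 percentage points lower from compound 2 to compound 3 (beyond the scatter).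

Compound 4, `CCCS(=O)(=O)Nc1ccc(F)c(C(=O)c2n[nH]c3ncc(-c4ccc(S(N)(=O)=O)cc4C)cc23)c1F`, has not yet been measured. It differs from compound 3 in one place: 2-methyl-4-sulfamoylphenyl in place of 4-(1H-tetrazol-5-yl)phenyl on an aromatic carbon. The group that enters is the sulfamoylphenyl group of compound 1 carrying an additional methyl on its six-membered ring. Among the measured compounds shown here, one measured step bears directly on the exchange of tetrazolyl for sulfamoyl: a number 4 percentage points lower from compound 1 to compound 3 (within the scatter). Undoing that exchange is therefore expected to move the number only slightly, back toward the value of compound 1, 5.1%. For the measured compounds named here, the methyl added to the ring has no counterpart among the measured compounds, so its effect is unknown and widens the range. For compound 4, the step in this assay is expected to be a number 4.9 percentage points higher from compound 3 to compound 4 (within the scatter), not beyond the scatter. Compound 4 is thus estimated at 6%, between 1% and 20%.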

Compound 4, a percentage reported as activity, at one concentration (the size of the read-out at that concentration, not a potency): 24%
Compound 4: the middle estimate sits 18 percentage points below what was measured; the measured number lies above the stated range.
By their numbers in this assay, from the lowest: compounds 3, 1, 2 and 4 (each within the scatter of the next, the first and the last beyond it).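

In this assay, among the compounds shown here, the phenyl ring itself proves sensitive to substitution: adding one methyl to the sulfamoylphenyl group gives a number 18.9 percentage points higher from compound 1 to compound 4 (beyond the scatter), the only single change on the sulfamoyl side that clearly weakens the effect. Exchanging the 4-(1H-tetrazol-5-yl)phenyl group for the 2-methyl-4-sulfamoylphenyl group gives a number 22.9 percentage points higher from compound 3 to compound 4 (beyond the scatter), whereas the comparison with the 4-(methylsulfamoyl)phenyl group gives a number 10 percentage points higher from compound 2 to compound 4 (within the scatter), so the ring methyl and the methyl on the sulfonamide nitrogen cannot be told apart in this assay. Nothing available explains why the ring methyl has this effect.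

On these data alone, it remains open whether the same methyl would raise the number on the 4-(1H-tetrazol-5-yl)phenyl group. As far as these compounds go, it is also open whether a chlorine atom, a methoxy group or an ethyl group on that ring carbon would behave like the methyl.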